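The source may hold more compounds than are shown below. What is called first, only, known or untested is meant among the compounds shown, and "the series" means these compounds.

In a functional assay on MDA-MB-435 cells (Homo sapiens) for cytotoxicity, read by MTT assay, with a stated time of 72 h (on this read-out higher numbers stand for weaker inhibition and lower numbers for stronger inhibition), compound 1 `N[C@H]1CC[C@H](Nc2c(C(=O)NCc3ccc(Oc4ccccc4)cc3)nc(Br)c3cccnc23)CC1` gives 4000 nM, the lowest of the two numbers obtained, and a value beyond the scatter from that of compound 3 `CS(=O)(=O)NCCCCCCN(c1nc(C(=O)NCc2ccc(F)cc2)c(O)c2ncccc12)S(C)(=O)=O`, which gives 20000 nM in this assay. Compound 2 `C[C@H](CO)Nc1nc(C(=O)NCc2ccc(F)cc2)c(O)c2ncccc12` reaches only the assay limit, > 20000 nM, in this assay, as noted in the limit of > 20000 nM in this assay, at which 1 of the 3 values shown sits. Compound 4 `N[C@H]1CC[C@H](Nc2c(C(=O)NCc3ccc(F)cc3)nc(Br)c3cccnc23)CC1` is not yet measured. It differs from compound 1 by fluoro in place of phenoxy on an aromatic carbon. Compounds 2 and 3 also carry fluoro, though on a different core, and both sit at weak values, so a loss of potency from compound 1 to compound 4 is expected, of about a 2.5-fold higher number from compound 1 to compound 4 (0.40 log units; beyond the scatter). In this assay compound 4 is therefore estimated at 10000 nM, within a range from 3000 nM to 20000 nM.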

Compound 4, half-maximal inhibitory concentration: 6000 nM
Estimate against measurement, compound 4: 1.7-fold (0.22 log units) above; measured number inside the range.
By their numbers in this assay, from the lowest: compounds 1 and 4 (each within the scatter of the next); then compound 3.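

In this assay, putting fluoro in place of phenoxy on an aromatic carbon, para to a large group, gives a 1.5-fold higher number from compound 1 to compound 4 (0.18 log units; within the scatter). This pair therefore shows that the phenoxy, with its six-membered aromatic ring of carbon only, can be replaced by a single fluorine atom at this position with no change that stands out from the scatter. The data shown offer no explanation for this outcome. On these data alone, it remains open whether an amine, a methoxy or a carboxylic acid at this position would also leave the number within the scatter.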